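The source may report more compounds than this note shows. Statements on the series, on what has been measured and on what is new or still open speak of the compounds shown alone.

Measured compounds:
- compound 1, `CSCC[C@H](NC1=CC(=O)C=C(C[C@]2(C)[C@@H](C)CC[C@]3(C)C(C)=CCC[C@@H]23)C1=O)C(=O)O`, in a functional assay on A549 cells (Homo sapiens) for cytotoxicity, read by MTT assay, with a stated time of 72 h (on this read-out lower numbers stand for stronger inhibition and higher numbers for weaker inhibition), compound 1 gives 47300 nM
- compound 2, `CC1=CCC[C@H]2[C@](C)(CC3=CC(=O)C=C(N[C@@H](C)C(=O)O)C3=O)[C@@H](C)CC[C@]12C`, in this assay compound 2 gives 54300 nM
- compound 3, `C[C@H](NC1=CC(=O)C=C(C(C)(C)C)C1=O)C(=O)O`; compound 3 reaches only the limit of this assay, reported as > 200000 nM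

Compound 2 and compound 1 share one core and differ in a single place: (methylsulfanyl)methyl in place of hydrogen on a saturated chain carbon, two bonds along the chain from an amine nitrogen and a carbonyl carbon. The step that this change made is a 1.1-fold lower number from compound 2 to compound 1 (0.06 log units; within the scatter), so within this pair the change left the read-out essentially unaltered.

Compound 3 carries a different core, and the difference between the two cores is not broken down here. Its value is a limit, not a number.

Compound 4, `CSCC[C@H](NC1=CC(=O)C=C(C(C)(C)C)C1=O)C(=O)O`, has not yet been measured in this assay. It stands to compound 3 as compound 1 stands to compound 2: (methylsulfanyl)methyl in place of hydrogen on a saturated chain carbon, two bonds along the chain from an amine nitrogen and a carbonyl carbon. The place of the change is the same in both pairs, so this is the same change made on the second core.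

The expectation for compound 4 rests on two things: the measured step of a 1.1-fold lower number from compound 2 to compound 1 (0.06 log units; within the scatter), which was within the scatter, and the fact that compound 3 sits at the limit of > 200000 nM in this assay, at which 1 of the 3 values shown sits. If the change behaves on the core of compound 3 as it did on the core of compound 2, the step of a number no higher from compound 3 to compound 4 (the limit leaves the size open) is expected to be small, and compound 4 is expected to remain at or close to the limit. The estimate for compound 4 in this assay is 200000 nM, spanning 80000 nM to 500000 nM, with a fair chance that only a limit is reported again.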

Compound 4, half-maximal inhibitory concentration: > 200000 nM
Compound 4: no number, only a limit (the forecaster's own chance of this, stated with the estimate: 65%); the middle value sits exactly at the limit.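

Compound 3 and compound 4 each reach only a limit in this assay, not a number, so no step can be read between them. The compounds shown leave open how compound 3 and compound 4 truly compare, and whether (methylsulfanyl)methyl in place of hydrogen does as little on this core as on the core of compound 2, since both values stop here: the limit of > 200000 nM in this assay, at which 2 of the 4 values shown sit.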